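Two dichlorophenyl patterns on two cores in one growth assay

The source may hold more compounds than are shown below. What is called first, only, known or untested is meant among the compounds shown, and "the series" means these compounds.

Compound 1 `Cc1ccc(NC(=O)Nc2cc(Cl)cc(Cl)c2)cc1NC(=O)c1cnoc1C`: > 30000 nM
Compound 2 `Cc1ccc(NC(=O)Nc2ccc(Cl)c(Cl)c2)cc1NC(=O)c1cnoc1C`: 1890 nM
Compound 3 `Cc1cc(NC(=O)Nc2ccc(Cl)c(Cl)c2)ccc1NC(=O)c1cnoc1C`: > 30000 nM

In a functional assay on U-937 cells (Homo sapiens) for antiproliferative activity, read by MTT assay, with a stated time of 24 h (on this read-out higher numbers stand for weaker inhibition of growth and lower numbers for stronger inhibition of growth), compound 2 gives 1890 nM. For compound 1 the assay reports only a limit, > 30000 nM. The change between them is 3,5-dichlorophenyl in place of 3,4-dichlorophenyl on an amide-type nitrogen, and it gives an at least 15-fold higher number from compound 2 to compound 1 (1.20 log units; beyond the scatter). Compound 3 also gives only a limit, > 30000 nM. The difference between the core of compound 2 and the core of compound 3 is not broken down here.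

Compound 4 `Cc1cc(NC(=O)Nc2cc(Cl)cc(Cl)c2)ccc1NC(=O)c1cnoc1C` has not yet been measured in this assay. It differs from compound 3 by 3,5-dichlorophenyl in place of 3,4-dichlorophenyl on an amide-type nitrogen, the same change that was made from compound 2 to compound 1, at the same place. Since compound 3 already sits at the limit, and the same change weakened compound 2 in the measured step, compound 4 is expected to sit at the limit as well, due to the limit of > 30000 nM in this assay, at which 2 of the 3 values shown sit. The step expected from compound 3 to compound 4 in this assay is a step that the limit leaves unreadable from compound 3 to compound 4. The estimate for compound 4 is 60000 nM, between 30000 nM and 150000 nM.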

Compound 4, concentration for 50% growth inhibition: > 30000 nM
Compound 4: a limit, no number; the forecaster's own chance of this, stated with the estimate: 90%; the middle value does not contradict the limit.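

In this assay compound 4 gives > 30000 nM, which is a limit and not a number. Among these compounds, compound 3 also stands at a limit, and no step between the two can be read. The compounds shown leave open whether 3,5-dichlorophenyl in place of 3,4-dichlorophenyl changes growth inhibition on the core of compound 3 at all.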